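The source may report more compounds than this note shows. Statements on the series, on what has been measured and on what is new or still open speak of the compounds shown alone.

Measured compounds:
- compound 1, `O=S(=O)(NCC1CCN(CCCc2c[nH]c3ccc(-n4cnnc4)cc23)CC1)c1ccccc1`, giving 6.2 nM in an assay on CHO cells for displacement of a labelled ligand from 5-hydroxytryptamine receptor 1D (Homo sapiens); a higher number here means a weaker inhibitor, a lower number a stronger inhibitor
- compound 2, `CC(C)=CCCN(C)C1CCN(CCCc2c[nH]c3ccc(-n4cnnc4)cc23)CC1`, giving 2.6 nM in this assay
- compound 3, `c1ccc2c(c1)CCC2NC1CCN(CCCc2c[nH]c3ccc(-n4cnnc4)cc23)CC1`, giving 8.9 nM in this assay

All three share the same core and differ only in the group carried on a saturated ring carbon. Compound 3 gives the highest number of the three, but its distance from compound 1 is small: a 1.4-fold higher number from compound 1 to compound 3 (0.16 log units; within the scatter). Its distance from compound 2 is larger: a 3.4-fold higher number from compound 2 to compound 3 (0.53 log units; beyond the scatter). Between compound 1 and compound 2 the step is a 2.4-fold lower number from compound 1 to compound 2 (0.38 log units; beyond the scatter).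

Compound 4, `C[C@@H](NC1CCN(CCCc2c[nH]c3ccc(-n4cnnc4)cc23)CC1)c1ccccc1`, keeps that core and the amine nitrogen of compound 3; the change is 1-phenylethyl in place of 2,3-dihydro-1H-inden-1-yl on an amine nitrogen. The entering group keeps a six-membered aromatic ring and drops the five-membered non-aromatic ring.

Going by the values given here, the steps that bear on this are the three exchanges at the same position among compounds 1, 2 and 3. They moved the number only modestly, although those groups differ from one another more than the two groups exchanged here. The step in this assay is therefore expected to be small, in either direction, most likely within the scatter: a 1.5-fold lower number from compound 3 to compound 4 (0.17 log units; within the scatter). Compound 4 is thus expected to give 6 nM in this assay, with a range from 2 nM to 18 nM.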

Compound 4, half-maximal inhibitory concentration: 0.4 nM
The estimate for compound 4 lay 15-fold (1.18 log units) above the measured number; measured number outside the range, below it.
By their numbers in this assay, from the lowest: compound 4; then compound 2; then compounds 1 and 3 (each within the scatter of the next).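

In this assay, going by these compounds alone, the exchange of 2,3-dihydro-1H-inden-1-yl for 1-phenylethyl on the amine nitrogen gives a 22-fold lower number from compound 3 to compound 4 (1.35 log units; beyond the scatter), a larger step than any among the earlier compounds, so this position can respond sharply even to a small change: both groups hold one six-membered aromatic ring of carbon only, and the entering group has just one heavy atom fewer. The same group also stands well clear of the other two substituents, with a 6.5-fold lower number from compound 2 to compound 4 (0.81 log units; beyond the scatter) and a 16-fold lower number from compound 1 to compound 4 (1.19 log units; beyond the scatter), which makes compound 4 the strongest inhibitor of the four. Nothing given here explains the size of this gain, as no supporting evidence bears on it.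

The compounds shown leave open how much of the gain depends on the defined stereocentre of the 1-phenylethyl group, which the mirror-image 1-phenylethyl group would test, and how much depends on its methyl, which a plain benzyl group would test. They also leave open whether a longer chain, such as 2-phenylethyl, would keep the number this low.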